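The compounds below may be only part of what the source reports. "The series", "measured", "known", "first", "only" and "open" are said of these compounds alone.

Measured compounds:
Compound 1, `O=C(Nc1ccc(OC(F)(F)F)cc1)c1cc(F)ccc1O`; in a functional assay on KG-1 cells (Homo sapiens) for cytotoxicity, read by luminescence and CellTiter-Glo, with a stated time of 3 days (a lower number here means a stronger inhibitor, a higher number a weaker inhibitor), compound 1 gives 780 nM.
Compound 2, `O=C(Nc1ccc(C(F)(F)F)cc1)c1cc(F)ccc1O`; compound 2 gives 1700 nM.
Compound 3, `O=C(Nc1cccc(C(F)(F)F)c1)c1cc(F)ccc1O`; compound 3 gives 1010 nM.

All three share the same amide-linked core carrying a hydroxyl and a fluorine, and differ only in the ring that the amide nitrogen bears. Compound 2 and compound 3 are built from the same atoms joined differently; the difference between these two cores is not broken down here. Compound 1 and compound 2 differ in one place, (trifluoromethoxy in place of trifluoromethyl on an aromatic carbon), and that change gave a 2.2-fold lower number from compound 2 to compound 1 (0.34 log units; beyond the scatter). Compound 3 stands within the scatter of both compound 1 and compound 2, so nothing can be said about order among those pairs.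

Compound 4, `O=C(Nc1cccc(OC(F)(F)F)c1)c1cc(F)ccc1O`, has not yet been measured. It differs from compound 3 by trifluoromethoxy in place of trifluoromethyl on an aromatic carbon. Going by the values given here, this is the same kind of change as the one from compound 2 to compound 1, not the same change: in compound 1 the new group sits para to a large group, while in compound 4 it sits meta to a large group. Among the compounds with values here, with only one earlier example of this kind of change, the expectation rests on that single step, a 2.2-fold lower number from compound 2 to compound 1 (0.34 log units; beyond the scatter), tempered by the different place. From compound 3 to compound 4 the expected step is a 1.8-fold lower number from compound 3 to compound 4 (0.26 log units; within the scatter). Compound 4 is estimated at 550 nM, with a likely range from 250 nM to 1200 nM.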

Compound 4, half-maximal inhibitory concentration: 830 nM
For compound 4 the middle estimate is 1.5-fold (0.18 log units) below the measured one; low and high end bracket the measured number.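

Placing trifluoromethoxy where compound 3 has trifluoromethyl, meta to a large group, gives a 1.2-fold lower number from compound 3 to compound 4 (0.09 log units; within the scatter), so in this assay this swap produces no readable difference between the two compounds. This does not set the second core apart from the first, as the two steps cannot be distinguished from each other: the same change on two cores in this assay, a 2.2-fold lower number (0.34 log units; beyond the scatter) from compound 2 to compound 1 and a 1.2-fold lower number (0.09 log units; within the scatter) from compound 3 to compound 4, 1.8-fold (0.25 log units) apart, within the scatter of two such steps The result therefore fits a similar effect on both cores but does not prove one, since the step from compound 2 to compound 1 lies beyond the scatter, the step from compound 3 to compound 4 lies within it, and two pairs are too few to show how reliably the change carries over.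

The compounds shown leave open how other groups at the same place on the ring, such as a nitrile, an amine, a carboxylic acid or a longer chain, would compare with trifluoromethyl and trifluoromethoxy in this assay. As far as these compounds go, all four compounds also keep the same hydroxyl and fluorine on the shared core, so the effect of replacing either of them, for example the hydroxyl with an amine, remains unknown.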